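A Methyl Added to the Fused Ring of Compound 2

A few compounds are considered here, and "the series" means these few. Any claim that something is new, unique, unknown or untested is made for them only; others in the source may bear on it.

Among the compounds with values here, compound 2 `Cc1cc(-c2nc3ccccc3o2)ccc1NC(=O)CCl` stands at the high end of the two numbers known here: in a functional assay on C6 cells (Rattus norvegicus) for cytotoxicity, read by MTT assay, with a stated time of 24 h (a higher number here means a weaker inhibitor, a lower number a stronger inhibitor), compound 2 gives 27200 nM, whereas compound 1 `Cc1ccc2oc(-c3ccc(NC(=O)CN4CCN(CCN(C)C)CC4)cc3)nc2c1` gives 1630 nM, a gap beyond the usual scatter. Compound 3 `Cc1ccc2oc(-c3ccc(NC(=O)CCl)c(C)c3)nc2c1` is not yet measured. It differs from compound 2 by methyl in place of hydrogen on an aromatic carbon of the fused ring system. Within the data shown here, no measured pair tracks this change, so no step beyond the scatter is expected in this assay. Compound 3 is therefore estimated at 22000 nM, with a range from 8000 nM to 60000 nM, a step of a 1.2-fold lower number from compound 2 to compound 3 (0.09 log units; within the scatter) being expected.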

Compound 3, half-maximal inhibitory concentration: 97600 nM
Compound 3: the middle estimate sits 4.4-fold (0.65 log units) below what was measured; the measured number lies above the stated range.
By their numbers in this assay, from the lowest: compound 1; then compound 2; then compound 3.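

In this assay, methyl in place of hydrogen on an aromatic carbon of the fused ring system proves not to be a silent change, giving a 3.6-fold higher number from compound 2 to compound 3 (0.55 log units; beyond the scatter). Within the data shown here, this single pair is the first reading at this position, and it points towards a weaker inhibitor. Nothing at hand accounts for the step. On these data alone, whether an ethyl or a methoxy group at the same carbon would move the number in the same direction remains open. So does whether the step would carry over to compounds with the side chain of compound 1.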